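This account rests on a few compounds, and the source may have more. Where it says the series, first, only, none or still open, it means among the compounds named here.

Among the measured compounds shown here, compound 1 `CO[C@@H]1[C@@H](OC)[C@H](c2ccccc2)O[C@@H]2CO[C@@H](c3ccc(Cl)cc3)O[C@@H]12` is the only member of this small set with a result in a functional assay on HEL cells (Homo sapiens) for cytotoxicity; on this read-out higher numbers stand for lower toxicity in this test and lower numbers for higher toxicity in this test. For compound 1 the value > 50 ug/mL is a limit of the assay rather than a number (the limit of > 50 ug/mL in this assay, at which 1 of the 2 values shown sits). Compound 2 `CO[C@@H]1[C@@H](OC)[C@H](c2ccccc2)O[C@@H]2CO[C@@H](c3cccc(Cl)c3)O[C@@H]12` carries in this assay only the entry "not determined" (no result reported), so it stands nowhere on the numbers shown. Compound 3 `CO[C@@H]1[C@@H](OC)[C@H](c2ccccc2)O[C@@H]2CO[C@@H](c3ccc(C(F)(F)F)cc3)O[C@@H]12` differs from it by 4-(trifluoromethyl)phenyl in place of 3-chlorophenyl on a saturated ring carbon. For the measured compounds named here, with no measured step to lean on, the change from compound 2 to compound 3 is expected to shift this assay by no more than the usual scatter, in no set direction. Compound 3 is estimated at 50 ug/mL, within 20 ug/mL to 100 ug/mL.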

Compound 3, half-maximal cytotoxic concentration: > 50 ug/mL
Compound 3 gave a limit, no number; the forecaster's own chance of this, stated with the estimate: 70%; the middle value lies on the limit itself.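

No step can be read from compound 1 to compound 3 in this assay, since both results are limits rather than numbers: the limit of > 50 ug/mL in this assay, at which 2 of the 3 values shown sit.

The compounds shown leave open whether trifluoromethyl in place of chloro changes this read-out at all, and where compound 2 stands.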